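A few compounds are considered here, and "the series" means these few. Any claim that something is new, unique, unknown or untested is made for them only; others in the source may bear on it.

For the measured compounds named here, in a functional assay on MCF7 cells (Homo sapiens) for antiproliferative activity, read by MTT assay, with a stated time of 48 h (a lower number here means a stronger inhibitor, a higher number a weaker inhibitor), compound 2 (`COc1ccc2[nH]c(-c3cn(-c4ccccc4)nc3-c3ccc(Cl)cc3)nc2c1`) gives 1760 nM, and its only measured neighbour, compound 1 (`Fc1ccc2[nH]c(-c3cn(-c4ccccc4)nc3-c3ccc(Cl)cc3)nc2c1`), gives 2830 nM. The two numbers lie within the scatter of each other. Compound 3 (`Cc1ccc2[nH]c(-c3cn(-c4ccccc4)nc3-c3ccc(Cl)cc3)nc2c1`) has not yet been measured. It carries methyl in place of methoxy on an aromatic carbon of the shared core: methyl in place of methoxy on an aromatic carbon. Going by the values given here, one measured step bears on this change, made at the same carbon: a 1.6-fold lower number from compound 1 to compound 2 (0.21 log units; within the scatter), with methoxy in place of fluoro. Among the compounds with values here, with only that step to go on, no shift beyond the scatter is expected in this assay, and the data indicate no firm direction. The expected step, a 1.3-fold higher number from compound 2 to compound 3 (0.10 log units; within the scatter), is therefore small. For compound 3 the estimated value is 2200 nM, with an expected range of 1100 nM to 4500 nM.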

Compound 3, half-maximal inhibitory concentration: 8230 nM
Compound 3: middle estimate off by 3.7-fold (0.57 log units), on the low side, outside the stated range (above it).
By their numbers in this assay, from the lowest: compounds 2 and 1 (each within the scatter of the next); then compound 3.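

In this assay this position proves sensitive to the group it carries: methyl in place of methoxy gives a 4.7-fold higher number from compound 2 to compound 3 (0.67 log units; beyond the scatter) and methyl in place of fluoro gives a 2.9-fold higher number from compound 1 to compound 3 (0.46 log units; beyond the scatter) while the earlier exchange of fluoro for methoxy stayed within the scatter. Methyl thus stands apart from both other groups at this aromatic carbon, and compound 3 is the weakest of the three in this series, with its steps to both others beyond the scatter. The data at hand give no measured explanation for this separation. Still open, from the compounds shown here alone, is how an amine, a carboxylic acid or an ethoxy group would read at this carbon. Also open, going by these compounds, is whether the gap between methyl and methoxy holds when the shared core is changed elsewhere.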